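Compound 3: phenyl replaces the substituted arylamino group

The source may report more compounds than this note shows. Statements on the series, on what has been measured and on what is new or still open speak of the compounds shown alone.

Measured so far:
- compound 1 `COc1cc(-c2nn(-c3cccc(NC(=O)Nc4cccc(C(F)(F)F)c4)c3)cc2-c2ccncc2)ccc1Cl`: 3200 nM
- compound 2 `COc1cc(-c2nn(-c3cccc(NC(=O)Nc4ccc(Cl)c(C(F)(F)F)c4)c3)cc2-c2ccncc2)ccc1Cl`: 7300 nM

Among the measured compounds shown here, in a functional assay on HCC 2998 cells (Homo sapiens) for inhibition, read by sulforhodamine B assay, with a stated time of 48 h (a higher number here means a weaker inhibitor of growth, a lower number a stronger inhibitor of growth), compound 2 stands at the higher of the two numbers, with compound 1 nearest to it; the one measured step, a 2.3-fold higher number from compound 1 to compound 2 (0.36 log units; beyond the scatter), separates them and it is a modest one. Compound 3 `COc1cc(-c2nn(-c3cccc(NC(=O)c4ccccc4)c3)cc2-c2ccncc2)ccc1Cl` has not yet been measured. It differs from compound 2 by phenyl in place of (4-chloro-3-(trifluoromethyl)phenyl)amino on a carbonyl carbon. For the measured compounds named here, no measured step covers a change of this kind: the step from compound 1 to compound 2 alters only a chloro on the aromatic ring of the leaving group, whereas here the whole (4-chloro-3-(trifluoromethyl)phenyl)amino group, with its hydrogen-bond donor, trifluoromethyl and chloro, is removed and a bare phenyl takes its place. The change is therefore much larger than anything the two measured compounds test, and the direction can only be guessed from the loss of the substituted group. The expectation is a step towards a higher number, a 2.1-fold higher number from compound 2 to compound 3 (0.31 log units; beyond the scatter), clearly beyond the scatter. Compound 3 is estimated at 15000 nM, within 4000 nM to 60000 nM.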

Compound 3, concentration for total growth inhibition: 22400 nM
The estimate for compound 3 lay 1.5-fold (0.17 log units) below the measured number; the measured number falls inside the stated range.
By their numbers in this assay, from the lowest: compound 1; then compound 2; then compound 3.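

Replacing the whole arylamino group on the carbonyl carbon with phenyl goes well beyond the ring chloro change seen so far, and in this assay it raises the number by both available routes: a 3.1-fold higher number from compound 2 to compound 3 (0.49 log units; beyond the scatter) and a 7.0-fold higher number from compound 1 to compound 3 (0.85 log units; beyond the scatter). Among these three compounds, phenyl therefore gives weaker growth inhibition than either (3-(trifluoromethyl)phenyl)amino or (4-chloro-3-(trifluoromethyl)phenyl)amino, even though the added chloro separating those two groups itself raised the number. No available evidence bears on the reason for this difference.

The amino nitrogen and the ring substituents leave together in these steps, so the compounds shown do not tell which of them accounts for the difference, and an unsubstituted phenylamino group on the same carbonyl carbon would help to separate them. Also open, from the compounds shown here alone, is whether an aromatic ring is needed at this position at all, a question that a methyl group or a morpholine on that carbonyl carbon would address.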